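The source may hold more compounds than are shown below. What is called first, only, known or untested is meant among the compounds shown, and "the series" means these compounds.

Series notes. Going by the values given here, compound 1 `Fc1ccc(-c2nc3cc(C(F)(F)F)ccc3[nH]2)cc1` and compound 2 `COc1ccc(-c2nc3cc(Cl)c(Cl)cc3[nH]2)c(N)c1` are the two measured members so far. In an ADME assay on MT4 cells (Homo sapiens) for cytotoxicity, read by MTT assay, with a stated time of 96 h (on this read-out higher numbers stand for lower toxicity in this test and lower numbers for higher toxicity in this test), compound 1 gives 22000 nM, which is the higher of the two numbers in hand. In this assay compound 2 gives 3000 nM, a lower number than that of compound 1, and the gap between the two lies beyond the scatter. The next compound keeps the core of compound 1: compound 3 `CC(=O)Nc1ccc(-c2nc3cc(C(F)(F)F)ccc3[nH]2)cc1` differs from it only in one place, with acetamido in place of fluoro on an aromatic carbon. Among the compounds with values here, no measured pair in hand carries this same change, so there is no direct precedent for its effect on this assay. The expected step is a 1.1-fold higher number from compound 1 to compound 3 (0.06 log units; within the scatter), small and not beyond the scatter. On that basis compound 3 is estimated at 25000 nM in this assay, with a range from 8000 nM to 70000 nM.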

Compound 3, half-maximal cytotoxic concentration: 19000 nM
Compound 3: the middle estimate sits 1.3-fold (0.12 log units) above what was measured; the range from low to high includes it.
By their numbers in this assay, from the lowest: compound 2; then compounds 3 and 1 (each within the scatter of the next).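

On the aromatic carbon para to a large group, acetamido in place of fluoro gives a 1.2-fold lower number from compound 1 to compound 3 (0.06 log units; within the scatter) in this assay, so on the core of compound 1 this position accepts the added heavy atoms, hydrogen-bond donor and hydrogen-bond acceptor with no shift beyond the scatter. Going by these compounds alone, this single pair is the only reading of the change so far, and it applies to this core alone. Nothing in hand accounts for the result.

Still open, from the compounds shown here alone, is whether an amine, a carboxylic acid or a longer acyl chain such as butyramido on this same carbon would also stay within the scatter of compound 1 or move the number beyond it. Also open, going by these compounds, is whether acetamido in place of fluoro behaves the same way on any other core.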